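A few compounds are considered here, and "the series" means these few. Any claim that something is new, unique, unknown or untested is made for them only; others in the source may bear on it.

Compound 1 `C=CC(C)(C)c1[nH]c2ccc(C[C@H](O)C(C)(C)O)cc2c1/C=c1\[nH]c(=O)c(=C)[nH]c1=O` and compound 2 `C=CC(C)(C)c1[nH]c2ccc(C[C@H](O)C(C)(C)OC)cc2c1/C=c1\[nH]c(=O)c(=C)[nH]c1=O` share one core, while compound 3 `C=CC(C)(C)c1[nH]c2c(C[C@H](O)C(C)(C)O)cccc2c1/C=C1\NC(=O)[C@H](C)NC1=O` and compound 4 `C=CC(C)(C)c1[nH]c2c(C[C@H](O)C(C)(C)OC)cccc2c1/C=C1\NC(=O)[C@H](C)NC1=O` share another; the difference between the two cores is not broken down here. All three measured compounds were tested in an ADME assay on MDCK cells (Canis lupus familiaris) for cytotoxicity, read by CellTiter-Glo, with a stated time of 40 h; on this read-out higher numbers stand for lower toxicity in this test and lower numbers for higher toxicity in this test. In this assay compound 1 gives > 200000 nM, which is a limit of the test rather than a number. Compound 2 in this assay gives > 200000 nM, again a limit. Compound 3 in this assay gives > 200000 nM, a limit as well.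

The change from compound 1 to compound 2 is methyl in place of hydrogen on an oxygen on a saturated carbon. For the measured compounds named here, the step it made, a step that the two limits leave unreadable from compound 1 to compound 2, cannot be read because of the limit of > 200000 nM in this assay, at which 3 of the 3 values shown sit, so the measured pair tells only that both compounds stay within the untoxic end of the test. The change from compound 3 to compound 4 is the same one, (methyl in place of hydrogen on an oxygen on a saturated carbon), at a place described in the same words.

For compound 4 the step expected in this assay is a step that the limit leaves unreadable from compound 3 to compound 4. This expectation rests on compound 1, which in this assay gives > 200000 nM, a limit. It rests likewise on compound 2, which in this assay gives > 200000 nM, the same limit, on the other side of this change. Compound 4 is therefore expected to give about 300000 nM in this assay, most likely reported as a limit again, with an estimated range from 150000 nM to 1000000 nM.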

Compound 4, half-maximal cytotoxic concentration: > 200000 nM
Compound 4 was reported as a limit; the forecaster's own chance of this, stated with the estimate: 85%; the middle value is on the limit's open side.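

No new step can be read from compound 3 to compound 4 in this assay, because both compounds sit at the same limit of the test, as do compounds 1 and 2: the limit of > 200000 nM in this assay, at which 4 of the 4 values shown sit. The compounds shown leave open how far each one lies past that limit, and so whether methyl in place of hydrogen on an oxygen on a saturated carbon changes cytotoxicity on either core.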